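The source may hold more compounds than are shown below. What is called first, only, known or untested is meant among the compounds shown, and "the series" means these compounds.

Values in a functional assay on PC-3 cells (Homo sapiens) for inhibition, read by sulforhodamine B assay (on this read-out lower numbers stand for stronger inhibition of growth and higher numbers for weaker inhibition of growth), for the series so far

compound 1 (`FC(F)(F)c1ccc(-c2ccc(-c3ccc(-c4nc5ccccc5[nH]4)cc3)cc2)cc1`) 45200 nM
compound 2 (`COc1cc(-c2ccc(-c3ccc(-c4nc5ccccc5[nH]4)cc3)cc2)cc(OC)c1OC`) 9720 nM
compound 3 (`Oc1cccc2[nH]c(-c3ccc(-c4ccc(-c5ccc(C(F)(F)F)cc5)cc4)cc3)nc12`) 2260 nM

Compound 3 holds the lowest of the three numbers, and its gaps to compound 2 and to compound 1 both lie beyond the scatter. The next compound is compound 4 (`Oc1cccc2[nH]c(-c3ccc(-c4ccc(-c5cccc(Cl)c5)cc4)cc3)nc12`), which keeps the core of compound 3 and exchanges one group. The change is 3-chlorophenyl in place of 4-(trifluoromethyl)phenyl on an aromatic carbon and, in words, 3-chlorophenyl in place of 4-(trifluoromethyl)phenyl, on an aromatic carbon, para to a large group.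

For the measured compounds named here, no measured step covers this exchange. Going by the values given here, the only step available is a 20-fold lower number from compound 1 to compound 3 (1.30 log units; beyond the scatter) and, although large, it concerns a hydroxy at another place in the molecule, so its size is not carried over. Compound 1 gives 45200 nM and compound 2 gives 9720 nM with different groups at the place now being changed, on a core without the hydroxy. Those two values show that the number can move with the group at this place, but they give no direction for 3-chlorophenyl. The step expected in this assay is a 1.1-fold higher number from compound 3 to compound 4 (0.04 log units; within the scatter) and no firm direction is expected. The estimate for compound 4 is 2500 nM with the range expected to run from 800 nM to 7500 nM on present data.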

Compound 4, concentration for 50% growth inhibition: 2560 nM
Compound 4: the middle estimate sits 1.0-fold (0.01 log units) below what was measured; the measured number falls inside the stated range.
By their numbers in this assay, from the lowest: compounds 3 and 4 (each within the scatter of the next); then compound 2; then compound 1.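

In this assay, the exchange of 4-(trifluoromethyl)phenyl for 3-chlorophenyl on an aromatic carbon, para to a large group, gives a 1.1-fold higher number from compound 3 to compound 4 (0.05 log units; within the scatter). For the compounds shown here, this is the first step measured at this position with the hydroxy present, and it shows that these two groups cannot be told apart in this assay, even though the exchange alters both the substituent and where it sits on the terminal ring. Going by these compounds alone, the single step cannot separate those two parts of the exchange, so the result describes this pair of groups and sets no general rule for the position, and no supporting measurement bears on this result.

The compounds shown leave open whether the level of compound 3 and compound 4 holds for other groups at this place, such as a phenyl ring carrying an amine or a carboxylic acid, or a longer chain in place of the ring. They also leave open how the group of compound 2 reads on the hydroxy core, and whether 4-chlorophenyl or 3-(trifluoromethyl)phenyl would read like the two groups compared here.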